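Lengthening the Oxime Chain on a Quinone Core

The source may hold more compounds than are shown below. What is called first, only, known or untested is meant among the compounds shown, and "the series" means these compounds.

Compound 2 `CCCCCCCO/N=C(\CCCCCC)c1cc(OC)c2c(c1OC)C(=O)C=CC2=O` gives 0.162 ug/mL in a functional assay on L1210 cells (Mus musculus) for antiproliferative activity; on this read-out lower numbers stand for an effect already at smaller amounts and higher numbers for an effect only at larger amounts of compound. For the measured compounds named here, compound 1 `CCCCCCCO/N=C/c1cc(OC)c2c(c1OC)C(=O)C=CC2=O` gives 0.213 ug/mL in this assay, a value that sits within the scatter of the one for compound 2, so the two are not told apart. Compound 3 `CCCCCCCCCO/N=C(\CCCCCC)c1cc(OC)c2c(c1OC)C(=O)C=CC2=O` differs from compound 2 by ethyl in place of hydrogen on a saturated chain carbon, seven bonds along the chain from an oxygen on an unsaturated carbon. Going by the values given here, no step between measured compounds isolates this change, so nothing beyond the scatter is expected from it, in either direction. Compound 3 is therefore estimated at 0.18 ug/mL, with a range from 0.07 ug/mL to 0.45 ug/mL, which means an expected step of a 1.1-fold higher number from compound 2 to compound 3 (0.05 log units; within the scatter).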

Compound 3, concentration for half-maximal effect: 1.15 ug/mL
Estimate against measurement, compound 3: 6.4-fold (0.81 log units) below, outside the stated range (above it).
By their numbers in this assay, from the lowest: compounds 2 and 1 (each within the scatter of the next); then compound 3.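

In this assay, ethyl in place of hydrogen on this saturated chain carbon gives a 7.1-fold higher number from compound 2 to compound 3 (0.85 log units; beyond the scatter), beyond the scatter. This shows that the chain tolerates no free lengthening at this position, something compounds 1 and 2 could not show, since they differ in another place. No available evidence bears on why the number rises. Still open, going by these compounds, is whether a longer chain raises the number further, or whether the rise appears only past a certain length. Also open, on these data alone, is how an amine or a carboxylic acid at this position would read.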